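The source may report more compounds than this note shows. Statements on the series, on what has been measured and on what is new or still open speak of the compounds shown alone.

In an assay on isolated protein for inhibition of vitamin D3 receptor (Homo sapiens), read by fluorescence polarization (on this read-out lower numbers stand for stronger inhibition and higher numbers for weaker inhibition), compound 1, with the structure `CS(=O)(=O)c1ccc(C(=O)N2CCC(C(=O)N3CCN(c4ccc(F)cc4)CC3)CC2)cc1[N+](=O)[O-]`, gives > 60000 nM, which is a limit of the assay and not a measured number. Compound 2, with the structure `CN(Cc1cccc(F)c1)C(=O)CCCNC(=O)c1ccc(S(C)(=O)=O)c([N+](=O)[O-])c1`, also reaches only a limit in this assay, > 60000 nM. Compound 3, with the structure `CS(=O)(=O)c1ccc(C(=O)NCCC(=O)N2CCCCC2)cc1[N+](=O)[O-]`, stands in this assay at a limit as well, > 60000 nM. Compound 3 therefore has no number of its own to stand on; what is known of it is the limit of > 60000 nM in this assay, at which 3 of the 3 values shown sit, shared with the other two compounds.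

Compound 4, with the structure `CS(=O)(=O)c1ccc(C(=O)NCCC(=O)N2CCc3ccccc32)cc1[N+](=O)[O-]`, differs from compound 3 in one place: 2,3-dihydro-1H-indol-1-yl in place of piperidin-1-yl on a carbonyl carbon. Within the data shown here, no step between two measured compounds is available, so this change has no measured counterpart to lean on. Because compound 3 sits at the limit of > 60000 nM in this assay, at which 3 of the 3 values shown sit, the step from compound 3 to compound 4 is expected to be a number no higher from compound 3 to compound 4 (the limit leaves the size open), nothing beyond the usual scatter. The value expected for compound 4 in this assay is 60000 nM, within a range from 25000 nM to 150000 nM.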

Compound 4, half-maximal inhibitory concentration: > 60000 nM
Compound 4 gave a limit, no number; the forecaster's own chance of this, stated with the estimate: 85%; the middle value lies on the limit itself.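

Compound 3 and compound 4 both give a limit of the assay and no number, so no step can be read between them: the limit of > 60000 nM in this assay, at which 4 of the 4 values shown sit.
In this assay the compounds shown leave open how strong an inhibition any of them reaches, and which change to the shared core would bring a measurable number.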